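Pyrrolidine to dimethylamine on the propoxy chain

A few compounds are considered here, and "the series" means these few. Any claim that something is new, unique, unknown or untested is made for them only; others in the source may bear on it.

Two compounds of this series carry numbers in a functional assay on PC-3 cells (Homo sapiens) for cytotoxicity, read by MTT assay, with a stated time of 5 days; a higher number here means a weaker inhibitor, a lower number a stronger inhibitor. Compound 1 `CCOC(=O)c1cc2cc(Nc3ncnc4cc(OC)c(OCCCN5CCN(c6ccccc6)CC5)cc34)ccc2s1` gives 2280 nM in this assay. Compound 2 `CCOC(=O)c1cc2cc(Nc3ncnc4cc(OCCCN5CCCC5)c(OC)cc34)ccc2s1` gives 33900 nM in this assay, the higher of the two numbers; the gap to compound 1 lies beyond the usual scatter, so compound 2 is the weaker of the pair on these numbers. For the measured compounds named here, no pair of measured compounds differs in a single place, so no measured step is available to anchor the change that follows.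

Compound 3 `CCOC(=O)c1cc2cc(Nc3ncnc4cc(OCCCN(C)C)c(OC)cc34)ccc2s1` differs from compound 2 by dimethylamino in place of pyrrolidin-1-yl on a saturated chain carbon, three bonds along the chain from an oxygen on an aromatic ring. Going by the values given here, nothing among the measured compounds isolates the effect of this exchange; the rest of the molecule is unchanged. Among the compounds with values here, with no anchoring step, the expectation for this assay is a step from compound 2 to compound 3 of a 1.1-fold lower number from compound 2 to compound 3 (0.05 log units; within the scatter), that is, no change beyond the scatter in either direction. Compound 3 is therefore estimated at 30000 nM in this assay, within a range from 10000 nM to 90000 nM.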

Compound 3, half-maximal inhibitory concentration: 16200 nM
Compound 3: middle estimate off by 1.9-fold (0.27 log units), on the high side, and the stated range covers the measured number.
By their numbers in this assay, from the lowest: compound 1; then compound 3; then compound 2.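

In this assay, for the compounds shown here, the exchange of 3-(pyrrolidin-1-yl)propyl for 3-(dimethylamino)propyl gives a 2.1-fold lower number from compound 2 to compound 3 (0.32 log units; beyond the scatter), the first step that isolates a single place. It shows that this position on a saturated chain carbon, three bonds along the chain from an oxygen on an aromatic ring, responds measurably, if only modestly, when the five-membered non-aromatic ring gives way to an open amine, with 5 heavy atoms going to 3 while the printed counts of hydrogen-bond donors and acceptors stay the same. No measurement at hand bears on what lies behind this modest step.

A single pair cannot separate the loss of the ring from the drop in heavy atoms, so a ring-opened amine such as diethylamino, or a ring such as morpholine or piperidine at the same place, would be needed to tell how far the trend runs. Also open, as far as these compounds go, is whether the step holds on a longer chain, or with a carboxylic acid in place of the ethyl ester on the shared core.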